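Solubility notes: piperidine ether series, compound 2 to compound 4

This account rests on a few compounds, and the source may have more. Where it says the series, first, only, none or still open, it means among the compounds named here.

Measured so far:
compound 1, `NC(=O)c1ccc2[nH]c(-c3ccc(OC4CCNCC4)cc3)nc2c1`: "not determined" (no result reported)
compound 2, `NC(=O)c1ccc2[nH]c(-c3ccc(OCC4CCNCC4)cc3)nc2c1`: > 400000 nM
compound 3, `NC(=O)c1ccc2[nH]c(-c3ccc(OCC4CCN(C(=O)c5ccccc5)CC4)cc3)nc2c1`: "not determined" (no result reported)

Three compounds of the series have entries in a physicochemical assay for solubility, with a stated time of 3 days, at pH 7 (a higher number here means a more soluble compound, a lower number a less soluble compound), and only one of them carries a value; compound 1 and compound 3 have no result reported. For compound 2 the entry is > 400000 nM, which is a limit of the assay and not a number. Within the data shown here, compound 2 therefore stands at the limit of > 400000 nM in this assay, at which 1 of the 3 values shown sits, so its true solubility is not pinned down, and no measured step between any two compounds exists in this assay to calibrate the effect of a change on the piperidine.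

Compound 4, `CC(=O)N1CCC(CCOc2ccc(-c3nc4cc(C(N)=O)ccc4[nH]3)cc2)CC1`, is the next compound to be measured. The change from compound 2 to compound 4 is (1-acetylpiperidin-4-yl)methyl in place of piperidin-4-yl on a saturated chain carbon bound to an oxygen on an aromatic ring.

Without a measured step to lean on, the expectation for this assay is a step downward from compound 2, larger than the scatter, because compound 2 sits at the limit of > 400000 nM in this assay, at which 1 of the 3 values shown sits, and any real drop would bring the value into the measurable range. Compound 4 is expected at 100000 nM, with a range from 20000 nM to 400000 nM. The estimated step of an at least 4.0-fold lower number from compound 2 to compound 4 (0.60 log units; beyond the scatter) is expected to be a decrease in solubility.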

Compound 4, solubility: 2000 nM
Compound 4: the middle estimate sits 50-fold (1.70 log units) above what was measured, outside the stated range (below it).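

Compound 2 gives > 400000 nM in this assay, which is a limit of the assay and not a number. Among these compounds, replacing piperidin-4-yl with (1-acetylpiperidin-4-yl)methyl on a saturated chain carbon bound to an oxygen on an aromatic ring gives an at least 200-fold lower number from compound 2 to compound 4 (2.30 log units; beyond the scatter), which shows that this assay responds strongly to a change at this place and provides the series with its only actual number, from compound 4. The printed size is only a lower bound on the step because one end of the comparison is not a number: the limit of > 400000 nM in this assay, at which 1 of the 4 values shown sits.

Among the compounds shown here, compound 1 and compound 3 have no result, so no steps involving them can be read, and the single readable step combines the acetyl on the ring nitrogen with the longer link, leaving their separate contributions unresolved. As far as these compounds go, it also remains open whether a basic tertiary amine at the same place, such as 1-methylpiperidin-4-yl on the same link as compound 2, would stay at the limit of this assay or fall toward compound 4.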